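A few compounds are considered here, and "the series" means these few. Any claim that something is new, unique, unknown or untested is made for them only; others in the source may bear on it.

Values in a physicochemical assay for solubility, measured as thermodynamic solubility, at pH 7.4 (a lower number here means a less soluble compound, a higher number a more soluble compound), so far:
- compound 1 `CC(=O)N1CCN(c2nc(NC(c3ccccc3)c3ccccc3)c3c(n2)C(=O)N(C(C)C)C3)CC1` gives < 1000 nM (a limit of the assay)
- compound 2 `CC(C)N1Cc2c(NC(c3ccccc3)c3ccccc3)nc(N3CCN(C(=O)CN(C)C)CC3)nc2C1=O` gives 50000 nM (a number)
- compound 3 `CC(=O)N1CCN(c2nc(NCc3ccccc3)c3c(n2)C(=O)N(C(C)C)C3)CC1` gives 230000 nM (a number)

Compound 3 (230000 nM) holds the higher of the two actual numbers, and compound 2 (50000 nM) holds the other. Compound 1 has a limit only.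

Still unmeasured is compound 4 `COc1ccc([C@@H](C)Nc2nc(N3CCN(C(C)=O)CC3)nc3c2CN(C(C)C)C3=O)cc1`, which departs from compound 3 as follows: 1-(4-methoxyphenyl)ethyl in place of benzyl on a nitrogen on an aromatic ring In words, 1-(4-methoxyphenyl)ethyl stands in place of benzyl on a nitrogen on an aromatic ring.

For the measured compounds named here, the nearest precedent is an at least 230-fold higher number from compound 1 to compound 3 (2.36 log units; beyond the scatter), a large step beyond the scatter that concerns the group on that same nitrogen. Read backwards, it pairs the bigger group with the far lower result, but it is a single pair. The other large step, an at least 50-fold higher number from compound 1 to compound 2 (1.69 log units; beyond the scatter), lies at a different place in the molecule and bears on this change only weakly.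

The entering group adds less than the phenyl of the precedent, so a lower number is expected, by a smaller margin than in that step. The expected move is a 5.8-fold lower number from compound 3 to compound 4 (0.76 log units; beyond the scatter), and it is estimated with wide uncertainty. The expected value for compound 4 is 40000 nM (estimated range 6000 nM to 160000 nM).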

Compound 4, solubility: 84000 nM
Estimate against measurement, compound 4: 2.1-fold (0.32 log units) below; the range from low to high includes it.
By their numbers in this assay, from the lowest: compounds 2 and 4 (each within the scatter of the next); then compound 3. At a limit, below all of these: compound 1.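

At this nitrogen on an aromatic ring, 1-(4-methoxyphenyl)ethyl in place of benzyl gives a 2.7-fold lower number from compound 3 to compound 4 (0.44 log units; beyond the scatter) in this assay, a modest step. For the compounds shown here, the only earlier pair at this place gave a large step, so a group with more heavy atoms than benzyl need not bring a large drop here, and compound 4 still gives 84000 nM. Compound 1 has a limit only, so the gap between its group and the others at this nitrogen has no number on one side: the limit of < 1000 nM in this assay, at which 1 of the 4 values shown sits.

The entering group differs from benzyl by its added methyl, its methoxy and its defined stereocentre all at once, and the compounds shown do not separate these three. Also open, going by these compounds, is what an amine or a carboxylic acid in place of the methoxy would give in this assay, and whether the dimethylamino group seen in compound 2 would shift the number when paired with 1-(4-methoxyphenyl)ethyl.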